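The compounds below may be only part of what the source reports. "The series", "measured", "known", "first", "only" and "open" are said of these compounds alone.

Measured compounds:
- compound 1 `CN(C(=O)NCCCOc1ccc2nc(O)ccc2c1)C1CCCCC1` — in a functional assay on the whole organism for inhibition, with Rattus norvegicus as the target, at a dose of 30 mg/kg by the oral route (on this read-out higher numbers stand for more inhibition at the one dose given (going by the name of the read-out) and lower numbers for less inhibition), compound 1 gives 15%
- compound 2 `O=C(NCCCOc1ccc2nc(O)ccc2c1)N(C1CCCC1)[C@H]1CCCC[C@@H]1O` — in this assay compound 2 gives 20%
- compound 3 `O=C(NCCCOc1ccc2nc(O)ccc2c1)N(C1CCCCC1)[C@H]1CCCC[C@@H]1O` — in this assay compound 3 gives 18%

Compound 3 has the middle of the three numbers, but both of its gaps to the others lie within the scatter, so the three values are indistinguishable on this read-out. The two one-place steps into compound 3 are a number 3 percentage points higher from compound 1 to compound 3 (within the scatter) and a number 2 percentage points lower from compound 2 to compound 3 (within the scatter); neither is a real change.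

Compound 4 `O=C(NCCCOc1ccc2nc(O)ccc2c1)N(C1CCCCCC1)[C@H]1CCCC[C@@H]1O` differs from compound 3 in one place: cycloheptyl in place of cyclohexyl on an amide-type nitrogen. The step that bears on this is the ring-size change on the same amide-type nitrogen, a number 2 percentage points lower from compound 2 to compound 3 (within the scatter), which stayed within the scatter. Nothing in the series shows a ring-size change at this nitrogen moving the read-out beyond the scatter, so for compound 4 a step of a number 1 percentage points lower from compound 3 to compound 4 (within the scatter) is expected, that is, no change beyond the scatter. Compound 4 is therefore estimated at 17% in this assay, with a likely range from 5% to 30%.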

Compound 4, a percentage reported as inhibition, in the whole organism at one dose (the size of the read-out at that dose, not a potency): 11%
Beside the measured number, compound 4's estimate is 6 percentage points above it, and the stated range covers the measured number.
By their numbers in this assay, from the lowest: compounds 4, 1, 3 and 2 (each within the scatter of the next).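

In this assay the change to cycloheptyl gives a number 7 percentage points lower from compound 3 to compound 4 (within the scatter), and the wider ring-size change on the same amide-type nitrogen gives a number 9 percentage points lower from compound 2 to compound 4 (within the scatter) for this pair. Cyclopentyl, cyclohexyl and cycloheptyl at this position therefore remain indistinguishable on this read-out, extending the earlier finding to a seven-membered non-aromatic ring of carbon only, although the step from cyclopentyl to cycloheptyl is the largest ring-size step seen here. No supporting measurement is available to explain these steps.

Going by these compounds, it remains open whether a group of a different kind at this nitrogen, such as a piperidinyl ring carrying an amine or an open butyl chain, would move the read-out beyond the scatter. On these data alone, the effect of a larger carbon ring, such as cyclooctyl, also remains open.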